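Enantiomer swap on the primary amide

The source may report more compounds than this note shows. Statements on the series, on what has been measured and on what is new or still open speak of the compounds shown alone.

The series rests on one measured number and one limit in an assay on isolated protein for inhibition of Apoptosis regulator Bcl-2 (Homo sapiens), read by fluorescence polarization, with stated times of 5 min and 10 min; on this read-out lower numbers stand for stronger inhibition and higher numbers for weaker inhibition. Compound 1 `CONC(=O)[C@@H]1CC=C(CCC=C(C)C)C[C@H]1c1ccccc1` gives 2700 nM in this assay. Compound 2 `CC(C)=CCCC1=CC[C@H](C(N)=O)[C@@H](c2ccccc2)C1` reaches only a limit in this assay, > 23000 nM; this is the assay boundary, not a number, and it stands as the limit of > 23000 nM in this assay, at which 1 of the 2 values shown sits. Compound 2 therefore sits at the weak end of what has been shown so far, with no finite value to place it.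

Compound 3 `CC(C)=CCCC1=CC[C@@H](C(N)=O)[C@H](c2ccccc2)C1` is the next step. Compared with compound 2, the change is the two compounds have the same atoms and bonds and differ only in configuration as drawn: 2 of 2 stereo elements differ (all stereocentres are inverted: mirror images); a stereocentre at a saturated ring carbon is drawn S in compound 2 and R in compound 3; a stereocentre at a saturated ring carbon is drawn S in compound 2 and R in compound 3. Nothing leaves and nothing enters; the whole difference is in the drawn configuration of the two ring stereocentres.

Among the compounds with values here, no step between two measured compounds is available to size this change. The expected step from compound 2 to compound 3 in this assay is an at least 4.6-fold lower number from compound 2 to compound 3 (0.66 log units; beyond the scatter), a move toward stronger inhibition, since a mirror image may bind differently and compound 2 gave only a limit. The expected value for compound 3 in this assay is 5000 nM, with a range from 1500 nM to 25000 nM.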

Compound 3, inhibition constant: > 23000 nM
Compound 3: a limit, no number; the forecaster's own chance of this, stated with the estimate: 20%; middle value at least 4.6-fold (0.66 log units) away from the limit.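

Compound 3 gives > 23000 nM in this assay, which is a limit and not a number, so the primary amide now reaches the limit in both mirror-image forms: the limit of > 23000 nM in this assay, at which 2 of the 3 values shown sit.

The step between the two mirror images cannot be read, and the effect of inverting both ring stereocentres therefore remains unsized: the fact that compounds 2 and 3 differ only in the configuration as drawn

The change on the amide nitrogen can be read, and hydrogen in place of methoxy gives an at least 8.5-fold higher number from compound 1 to compound 3 (0.93 log units; beyond the scatter), a move toward weaker inhibition that leaves the methoxy amide, compound 1, as the only compound shown with a finite value.

Still open, on these data alone, is whether the mirror image of compound 1 keeps a finite value, which would show whether configuration matters once the methoxy group is on the nitrogen. Also open, as far as these compounds go, is how other groups behave at this position, such as an ethoxy or a methyl on the amide nitrogen, or a carboxylic acid in place of the amide.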